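Swapping Cyclopropyl for Fluoro on the Aromatic Ring

This account rests on a few compounds, and the source may have more. Where it says the series, first, only, none or still open, it means among the compounds named here.

Of the compounds shown here, three built on one shared core have been tested in a functional assay on HOS-TE85 cells (Homo sapiens) for inhibition, read by CCK-8 assay, with a stated time of 72 h; on this read-out lower numbers stand for stronger inhibition and higher numbers for weaker inhibition. Compound 1 `COc1ccccc1N1C(=O)C(C)SC1c1cccc(C(=O)NCCCCc2ccccc2)c1` gives 45.1 nM. Compound 2 `COc1ccccc1N1C(=O)CSC1c1cccc(C(=O)NCCCCn2cccn2)c1` gives 91.7 nM in this assay. Compound 3 `COc1ccccc1N1C(=O)CSC1c1cc(C(=O)NCCCCc2ccccc2)cc(C2CC2)c1` gives 23.5 nM in this assay, the lowest of the three numbers; its gap to compound 1 lies within the usual scatter of repeated measurements, while its gap to compound 2 lies beyond that scatter.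

Compound 4 `COc1ccccc1N1C(=O)CSC1c1cc(F)cc(C(=O)NCCCCc2ccccc2)c1` has not yet been measured. It differs from compound 3 in a single place: fluoro in place of cyclopropyl on an aromatic carbon. No pair of measured compounds differs in exactly one place, so this change has no measured counterpart among the compounds shown, and nothing here points to a direction for it. Compound 4 is therefore expected to give roughly 40 nM in this assay, with a range from 15 nM to 110 nM. The estimate implies a step of a 1.7-fold higher number from compound 3 to compound 4 (0.23 log units; within the scatter) that is expected to stay within the scatter, with no clear direction beyond it.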

Compound 4, half-maximal inhibitory concentration: 40.9 nM
Compound 4: the middle estimate sits 1.0-fold (0.01 log units) below what was measured; low and high end bracket the measured number.
By their numbers in this assay, from the lowest: compounds 3, 4 and 1 (each within the scatter of the next); then compound 2.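

In this assay, fluoro in place of cyclopropyl on this aromatic carbon gives a 1.7-fold higher number from compound 3 to compound 4 (0.24 log units; within the scatter), the first comparison among these compounds in which only one place changes. On this read-out, a single fluorine atom and a three-membered carbon ring cannot be told apart at this position, so the ring is not required for a number in this range. Nothing available here explains why the two groups give such similar results.

As far as these compounds go, it remains open whether an amine, a carboxylic acid or a longer carbon chain on this aromatic carbon would stay within the same range. A single pair also cannot show whether this swap would have a similarly small effect on other compounds with different side chains.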